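The source may hold more compounds than are shown below. What is called first, only, known or untested is meant among the compounds shown, and "the series" means these compounds.

Measured compounds:
compound 1 `C=CCn1c(=O)/c(=C\c2cccc(F)c2)[nH]c(=O)/c1=C\c1ccccc1OC` — in a functional assay on BGC-823 cells (Homo sapiens) for cytotoxicity, read by CCK-8 assay, with a stated time of 72 h (on this read-out higher numbers stand for weaker inhibition and lower numbers for stronger inhibition), compound 1 gives 5600 nM.
compound 2 `C=CCn1c(=O)/c(=C\c2ccccc2C(F)(F)F)[nH]c(=O)/c1=C\c1ccccc1OC` — compound 2 gives 5100 nM.
compound 3 `C=CCn1c(=O)/c(=C\c2ccc(C)cc2)[nH]c(=O)/c1=C\c1ccccc1OC` — compound 3 gives "not active" (no number reported), with no number given.

Compound 3 thus stands apart from compounds 1 and 2 on the numbers shown, having no number of its own. Compound 4 `C=CCn1c(=O)/c(=C\c2cccc(C)c2)[nH]c(=O)/c1=C\c1ccccc1OC` differs from compound 3 by 3-methylphenyl in place of 4-methylphenyl on a double-bonded chain carbon bound to an aromatic carbon. Among the compounds with values here, only one measured step concerns the same place in the molecule: a 1.1-fold lower number from compound 1 to compound 2 (0.04 log units; within the scatter), a change between different groups that stayed within the scatter. Nothing measured shows what moving a methyl group does in this assay, and compound 3 offers no number to step from. The outcome is open. Compound 4 is expected to remain weak, estimated near 9000 nM, within a range of 3000 nM to 40000 nM, and it may again be reported only as inactive.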

Compound 4, half-maximal inhibitory concentration: 20400 nM
Beside the measured number, compound 4's estimate is 2.3-fold (0.36 log units) below it; low and high end bracket the measured number.
By their numbers in this assay, from the lowest: compounds 2 and 1 (each within the scatter of the next); then compound 4.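

In this assay there is a 3.6-fold higher number from compound 1 to compound 4 (0.56 log units; beyond the scatter) and a 4.0-fold higher number from compound 2 to compound 4 (0.60 log units; beyond the scatter) so the group at this position can shift the number beyond the scatter, which the earlier step did not show. Compound 3 has no number, so moving the methyl from 4-methylphenyl to 3-methylphenyl cannot be read as a step. No measurement here explains these shifts.

As far as these compounds go, whether an amine or a carboxylic acid on this phenyl ring would bring the number lower stays open, as does the effect of a longer chain in place of the methyl.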